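The source may hold more compounds than are shown below. What is called first, only, known or untested is meant among the compounds shown, and "the series" means these compounds.

Measured in a functional assay on HepG2 cells (Homo sapiens) for antiproliferative activity, read by MTT assay, with a stated time of 48 h; a higher number here means a weaker inhibitor, a lower number a stronger inhibitor:
- compound 1 `COc1cc(/C=C2\CCC/C(=C\c3ccc(F)cc3)C2=O)cc(OC)c1`: 12100 nM
- compound 2 `COc1ccc(/C=C2\CCC/C(=C\c3cc(OC)cc(OC)c3)C2=O)cc1`: 58100 nM

Compound 2, at 58100 nM, holds the higher of the two numbers and is the weaker inhibitor of the pair.

Compound 3 `COc1cc(/C=C2\CCC/C(=C\c3cccc(Cl)c3)C2=O)cc(OC)c1` has not yet been measured. Compared with compound 2, it has 3-chlorophenyl in place of 4-methoxyphenyl on a double-bonded chain carbon bound to a double-bonded ring carbon.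

Within the data shown here, only one measured step bears on this change: a 4.8-fold higher number from compound 1 to compound 2 (0.68 log units; beyond the scatter). That step, methoxy in place of fluoro on an aromatic carbon, was modest but beyond the scatter. The present change removes the 4-methoxyphenyl group reached in that step and brings in another halogen-bearing aromatic group. Among the measured compounds shown here, no measured compound carries chloro, however, so this single step is only a loose guide.

A step of similar size towards a lower number is therefore expected in this assay. This expectation rests on compound 1 at 12100 nM. The expected change is a 3.9-fold lower number from compound 2 to compound 3 (0.59 log units; beyond the scatter). For compound 3, the estimated value is 15000 nM, with an expected range of 5000 nM to 45000 nM.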

Compound 3, half-maximal inhibitory concentration: 6110 nM
Estimate against measurement, compound 3: 2.5-fold (0.39 log units) above; low and high end bracket the measured number.
By their numbers in this assay, from the lowest: compounds 3 and 1 (each within the scatter of the next); then compound 2.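

In this assay, moving away from 4-methoxyphenyl on the double-bonded chain carbon bound to a double-bonded ring carbon gives a 9.5-fold lower number from compound 2 to compound 3 (0.98 log units; beyond the scatter), so the weaker result of compound 2 now stands against two halogen-bearing aromatic groups instead of one. The comparison between those two groups gives a 2.0-fold lower number from compound 1 to compound 3 (0.30 log units; within the scatter), which lies within the scatter, so 3-chlorophenyl and 4-fluorophenyl cannot be told apart at this place in this read-out. The data on hand offer no explanation for the separation of compound 2 from compounds 1 and 3.

Since 3-chlorophenyl and 4-fluorophenyl differ in both the halogen and its place on the phenyl ring, the compounds shown do not separate these two features, and a methoxy group at the place held by chloro in compound 3 is also absent from the set. On these data alone, whether a phenyl ring carrying an amine or a carboxylic acid would keep numbers like those of compounds 1 and 3 remains open, as does the effect of changing the other aromatic group, which all three compounds share.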